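From bromo to hydroxy on a barely active compound

This account rests on a few compounds, and the source may have more. Where it says the series, first, only, none or still open, it means among the compounds named here.

Compound 1 (`O=S(=O)(/C=C/c1ccc(Br)cc1)Cc1ccc(Nc2ncnc3ccccc23)cc1`) sits at the weak end of the scale. In a functional assay on U-251 cells (Homo sapiens) (on this read-out lower numbers stand for stronger inhibition of growth and higher numbers for weaker inhibition of growth), compound 1 gives > 100000 nM, which is a limit of the assay and not a number.

Compound 4 (`O=S(=O)(/C=C/c1ccc(O)cc1)Cc1ccc(Nc2ncnc3ccccc23)cc1`) differs in one place, with hydroxy in place of bromo on an aromatic carbon.

For the measured compounds named here, only one measured step starts from compound 1, and it changes the same aromatic ring: a number no higher from compound 1 to compound 3 (the limit leaves the size open). Compound 3 (`O=S(=O)(/C=C/c1ccc(F)cc1Cl)Cc1ccc(Nc2ncnc3ccccc23)cc1`) gives 100000 nM. On these data alone, the size of that step remains unknown. Compound 2 (`CC(C)(C)c1cc(/C=C/S(=O)(=O)Cc2ccc(Nc3ncnc4ccccc34)cc2)cc(C(C)(C)C)c1O`) is the closest guide, since it also carries a hydroxy group on that ring, together with two tert-butyl groups. Compound 2 gives 38000 nM.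

A small move towards stronger inhibition therefore seems likely, though compound 4 may stay at the limit. The expected step is an at least 1.6-fold lower number from compound 1 to compound 4 (0.22 log units; that floor lies within the scatter). For compound 4 the estimated value is 60000 nM, with an expected range from 20000 nM to 100000 nM.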

Compound 4, concentration for 50% growth inhibition: 300 nM
Beside the measured number, compound 4's estimate is 200-fold (2.30 log units) above it; the measured number lies below the stated range.
By their numbers in this assay, from the lowest: compound 4; then compound 2; then compound 3.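

Putting hydroxy in place of bromo on this aromatic carbon gives an at least 330-fold lower number from compound 1 to compound 4 (2.52 log units; beyond the scatter), so a change of a single heavy atom here can carry a compound far from the weak end of the scale in this assay. Replacing 2-chloro-4-fluorophenyl with 4-hydroxyphenyl gives a 330-fold lower number from compound 3 to compound 4 (2.52 log units; beyond the scatter), which shows that this large drop does not depend on starting from a limit. The value of compound 1 is a limit and not a number, so the first step gives only a floor for the change: the limit of > 100000 nM in this assay, at which 1 of the 4 values shown sits.

The compounds shown leave open whether a methoxy group or an amine on the same carbon would keep this strong inhibition. They also leave open how the tert-butyl groups act, since compound 2 carries hydroxy alongside two of them and gives 38000 nM.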